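A few compounds are considered here, and "the series" means these few. Any claim that something is new, unique, unknown or untested is made for them only; others in the source may bear on it.

Measured compounds:
- Compound 1 `CC#CC1=Nc2ccccc2C(C)(C)O1` with 8400 nM
- Compound 2 `C#Cc1nc(C(=O)Nc2ccc(Cl)cc2)cs1` with 540 nM

In a functional assay on NCI-H522 cells (Homo sapiens) for cytotoxicity, with a stated time of 3 days (a higher number here means a weaker inhibitor, a lower number a stronger inhibitor), compound 1 stands highest of the two, and its number lies beyond the scatter from that of compound 2. Compound 3 `C#CC1=Nc2ccccc2C(C)(C)O1` keeps the core of compound 1 and differs by hydrogen in place of methyl on a triple-bonded carbon in one place, with hydrogen in place of methyl on a triple-bonded carbon. Going by the values given here, no measured pair shows this change. Compound 2 at 540 nM also carries an ethynyl group, which gives modest support for expecting a lower number. The estimate implies a 5.6-fold lower number from compound 1 to compound 3 (0.75 log units; beyond the scatter) as the expected step, toward stronger inhibition and beyond the scatter. Compound 3 is expected at 1500 nM within an estimated range of 300 nM to 7000 nM in this assay when measured.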

Compound 3, half-maximal inhibitory concentration: 890 nM
For compound 3 the middle estimate is 1.7-fold (0.23 log units) above the measured one; low and high end bracket the measured number.
By their numbers in this assay, from the lowest: compounds 2 and 3 (each within the scatter of the next); then compound 1.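

In this assay the change from prop-1-yn-1-yl to ethynyl on the shared core gives a 9.4-fold lower number from compound 1 to compound 3 (0.97 log units; beyond the scatter) and so shows that this position responds to the loss of a single methyl. Going by these compounds alone, this is the first pair to isolate hydrogen in place of methyl on a triple-bonded carbon, a comparison that compound 2, with its different core, could not offer. Nothing measured here explains the direction or size of this step.

The compounds shown leave open how a longer chain or an amine on the triple-bonded carbon would read in this assay and whether the same change would give a similar step on another core.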